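Replacing 3-hydroxyphenyl in compound 1 with 2-methoxyphenyl

This account rests on a few compounds, and the source may have more. Where it says the series, first, only, none or still open, it means among the compounds named here.

- Compound 1 `COc1cc(NC(=O)/C=C/c2cccc(O)c2)cc(OC)c1OC`: 18700 nM
- Compound 2 `COc1cc(NC(=O)/C=C/c2cc(OC)c(OC)c(OC)c2)cc(OC)c1`: 38900 nM
- Compound 3 `COc1ccc(NC(=O)/C=C/c2cc(OC)c(OC)c(OC)c2)cc1`: > 50000 nM (a limit of the assay, not a number)

In a functional assay on HeLa cells (Homo sapiens) for cytotoxicity, read by sulforhodamine B assay, with a stated time of 72 h (on this read-out lower numbers stand for stronger inhibition and higher numbers for weaker inhibition), compound 1 gives 18700 nM, the lowest of the numbers shown. The nearest number belongs to compound 2 at 38900 nM, and that gap lies beyond the usual scatter. The entry for compound 3 is a limit, > 50000 nM, not a number.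

Compound 4 `COc1ccccc1/C=C/C(=O)Nc1cc(OC)c(OC)c(OC)c1` has not yet been measured. It carries 2-methoxyphenyl in place of 3-hydroxyphenyl on a double-bonded chain carbon bound to a double-bonded chain carbon. Within the data shown here, no measured pair of compounds isolates this kind of change, so the expectation rests on thin ground. Compound 1 holds the lowest number, and compound 2 at 38900 nM marks the next value up, so a modest move toward weaker inhibition is expected. In this assay the expected step is a 1.7-fold higher number from compound 1 to compound 4 (0.23 log units; within the scatter).

For compound 4 the estimated value is 32000 nM, with an expected range from 14000 nM to 70000 nM.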

Compound 4, half-maximal inhibitory concentration: 6100 nM
Beside the measured number, compound 4's estimate is 5.2-fold (0.72 log units) above it; the whole stated range lies above it.
By their numbers in this assay, from the lowest: compound 4; then compound 1; then compound 2. At a limit, above all of these: compound 3.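

Among these compounds, compound 4 gives the first comparison here between two compounds that differ in one place. In this assay, putting 2-methoxyphenyl in place of 3-hydroxyphenyl on the double-bonded chain carbon gives a 3.1-fold lower number from compound 1 to compound 4 (0.49 log units; beyond the scatter), so this position can accept a change that strengthens inhibition. The entering group has no hydrogen-bond donor, which shows that the donor counted on 3-hydroxyphenyl is not required for inhibition at this level, though nothing measured here gives a reason for the gain.

This single step changes both the group and its numbered ring position, so it cannot say which of the two matters. Results for 2-hydroxyphenyl and 3-methoxyphenyl would separate the two, and 2-aminophenyl would test whether an amine can stand in for the methoxy group.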